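Spiro-fused phenyl substituent swap under a detection limit

The source may report more compounds than this note shows. Statements on the series, on what has been measured and on what is new or still open speak of the compounds shown alone.

Compound 1, `CC1COC2(C=CC(=O)C=C2)N(C(C)C)C1=O`, in an assay on isolated protein for inhibition of N-lysine methyltransferase SMYD2 (Homo sapiens), read by filter binding, with a stated time of 1 h; on this read-out lower numbers stand for stronger inhibition and higher numbers for weaker inhibition: > 20000 nM.
Compound 2, `CC(C)N1C(=O)C(Cc2ccc(F)cc2)COC12C=CC(=O)C=C2`, in this assay: > 20000 nM.

Both numbers shown for this pair are limits of the assay rather than measured values. For compound 1 the value > 20000 nM in this assay is such a limit. For compound 2 the value > 20000 nM in this assay is again only a limit, so where compound 2 stands among these numbers cannot be read more closely than that. Within the data shown here, the one measured step between them, a step that the two limits leave unreadable from compound 1 to compound 2, is therefore unreadable in size, and the limit of > 20000 nM in this assay, at which 2 of the 2 values shown sit, is all the evidence the numbers give.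

Compound 3, `CC(C)N1C(=O)C(Cc2cccc(Br)c2)COC12C=CC(=O)C=C2`, has not yet been measured. It differs from compound 2 by 3-bromophenyl in place of 4-fluorophenyl on a saturated chain carbon bound to a saturated ring carbon. Among the measured compounds shown here, no measured step speaks to a change of this kind, and the only step in hand is itself unreadable. Compound 3 is therefore expected to stay where compound 2 stands, with the step that the limit leaves unreadable from compound 2 to compound 3 expected to be none beyond the scatter. The estimate for compound 3 in this assay is 25000 nM, with a range from 8000 nM to 80000 nM.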

Compound 3, half-maximal inhibitory concentration: > 20000 nM
Compound 3: only a limit was reported (the forecaster's own chance of this, stated with the estimate: 80%); the middle value does not contradict the limit.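

In this assay compound 3 gives > 20000 nM, which is again a limit of the assay. Among these compounds, no new step can therefore be read among compound 1, compound 2 and compound 3. The compounds shown leave open how strongly any of them inhibits the enzyme, and whether either phenyl substituent changes that at all: the limit of > 20000 nM in this assay, at which 3 of the 3 values shown sit.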